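The compounds below may be only part of what the source reports. "The series", "measured", "known", "first", "only" and "open" are said of these compounds alone.

Of the compounds shown here, three have been measured in an assay for inhibition of protein disulfide-isomerase (Homo sapiens), with a stated time of 1 h; on this read-out lower numbers stand for stronger inhibition and higher numbers for weaker inhibition: compound 1 `Oc1ccc2[nH]ncc2c1C(c1ccc(-n2cccc2)cc1)N1CCCCC1` with 290 nM, compound 3 `Oc1c(C(c2ccc(F)cc2)N2CCCCC2)ccc2scnc12` with 570 nM, and compound 2 `Cc1ccnc(NC(c2ccccc2C)c2ccc3cccnc3c2O)c1`. In this assay compound 2 gives > 40000 nM, a limit and not a number, which is the limit of > 40000 nM in this assay, at which 1 of the 3 values shown sits. Compound 4 `CCc1ccc(C(Nc2cc(C)ccn2)c2ccc3cccnc3c2O)cc1` differs from compound 2 in one place: 4-ethylphenyl in place of 2-methylphenyl on a saturated chain carbon bound to an aromatic carbon and a nitrogen on an aromatic ring. For the measured compounds named here, no measured pair shows what such a change does, so the expectation rests on compound 2 alone. The step of a number no higher from compound 2 to compound 4 (the limit leaves the size open) is expected to be none beyond the scatter. Compound 4 is therefore expected to give about 40000 nM, with a range from 15000 nM to 100000 nM, most likely again reported only as a limit.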

Compound 4, half-maximal inhibitory concentration: 5390 nM
Beside the measured number, compound 4's estimate is 7.4-fold (0.87 log units) above it, outside the stated range (below it).
By their numbers in this assay, from the lowest: compounds 1 and 3 (each within the scatter of the next); then compound 4. At a limit, above all of these: compound 2.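

In this assay, the group on this saturated chain carbon does matter: 4-ethylphenyl in place of 2-methylphenyl gives an at least 7.4-fold lower number from compound 2 to compound 4 (0.87 log units; beyond the scatter). A single change at this place is thus enough to bring a measurable number, which compounds 1 and 3 could not show. Compound 2 is reported only as a limit, so the full size of the step stays open: the limit of > 40000 nM in this assay, at which 1 of the 4 values shown sits.

The ethyl group and its place on the phenyl ring change together here, and the compounds shown do not separate the two. They also leave open how an amine or a carboxylic acid on that ring would read.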